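Trifluoromethyl for hydroxy on the benzamide arm

This account rests on a few compounds, and the source may have more. Where it says the series, first, only, none or still open, it means among the compounds named here.

Measured so far in an ADME assay on Karpas-1106P cells (Homo sapiens) for cytotoxicity; a higher number here means that more compound is needed for the effect, a lower number that less compound is needed:
compound 1 `Cc1ccc(S(=O)(=O)N[C@@H](CC(=O)NC(C)(C)C)C(=O)NCCNC(=O)c2cc(Cl)ccc2Cl)cc1` gives > 11100 nM
compound 2 `Cc1ccc(S(=O)(=O)N[C@@H](CC(=O)NC(C)(C)C)C(=O)NCCNC(=O)c2cccc(O)c2)cc1` gives > 11100 nM

In this assay compound 1 reaches only a limit, > 11100 nM. Compound 2 likewise reaches only a limit, > 11100 nM. Both readings sit at the limit of > 11100 nM in this assay, at which 2 of the 2 values shown sit, so the step that the two limits leave unreadable from compound 1 to compound 2 cannot be read in either direction. Going by the values given here, compound 2 therefore stands at the limit of this assay, without a number of its own, as does the one other compound measured.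

Compound 3 `Cc1ccc(S(=O)(=O)N[C@@H](CC(=O)NC(C)(C)C)C(=O)NCCNC(=O)c2cccc(C(F)(F)F)c2)cc1` differs from compound 2 by trifluoromethyl in place of hydroxy on an aromatic carbon. Among the compounds with values here, the only measured step is the unreadable one from compound 1 to compound 2, so no measured step gives a size for this change. With both readings at the limit of > 11100 nM in this assay, at which 2 of the 2 values shown sit, the expectation is that compound 3 also sits at the limit in this assay, and the step that the limit leaves unreadable from compound 2 to compound 3 is expected to be within the scatter. Compound 3 is estimated at 15000 nM, ranging from 5000 nM to 50000 nM.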

Compound 3, half-maximal effective concentration: > 11100 nM
Compound 3 gave a limit, no number (the forecaster's own chance of this, stated with the estimate: 80%); the middle value does not contradict the limit.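

Compound 3 also gives only a limit in this assay, so the steps to it from compound 1 and from compound 2 cannot be read: the limit of > 11100 nM in this assay, at which 3 of the 3 values shown sit. None of the three compounds has a number of its own, which leaves open whether these changes on the benzamide arm alter cytotoxicity at all.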